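A few compounds are considered here, and "the series" means these few. Any claim that something is new, unique, unknown or untested is made for them only; others in the source may bear on it.

Compound 1 `Cn1c(-c2ccc(NC(=O)CSc3nc4ccccc4o3)cc2)nc(-c2ccccc2)c1-c1ccccc1` and compound 2 `Cn1c(-c2ccc(NC(=O)CSc3nc4cc(Cl)ccc4o3)cc2)nc(-c2ccccc2)c1-c1ccccc1` share one core and differ only in a chloro in place of hydrogen on an aromatic carbon. In a functional assay on HT-29 cells (Homo sapiens) for cytotoxicity, read by MTT assay, with a stated time of 24 h, tested at 80 ug/mL (on this read-out higher numbers stand for a stronger effect at the one concentration tested and lower numbers for a weaker effect), compound 1 gives 81.5%. In the same this assay compound 2 gives 79.6%. The step of a number 1.9 percentage points lower from compound 1 to compound 2 (within the scatter) lies within the scatter. For the measured compounds named here, of the two numbers, compound 2 has the smaller one, yet since its only neighbour is compound 1 at a distance within the scatter, the two cannot be told apart.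

Compound 3 `Cc1ccc2oc(SCC(=O)Nc3ccc(-c4nc(-c5ccccc5)c(-c5ccccc5)n4C)cc3)nc2c1` is the next step from compound 2. The change is methyl in place of chloro on an aromatic carbon. Going by the values given here, no measured step swaps chloro for methyl. Among the compounds with values here, the only step that touches the same aromatic carbon is the step from compound 1 to compound 2, chloro in place of hydrogen, which was within the scatter. Within the data shown here, a small group exchanged for another small group at a position where the one earlier change left the read-out unchanged gives no ground to expect a shift in this assay beyond the scatter. Compound 3 is therefore expected to show a step of a number 0.4 percentage points higher from compound 2 to compound 3 (within the scatter). For compound 3 the estimated value in this assay is 80%, expected to fall between 68% and 90%.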

Compound 3, a percentage reported as activity, at one concentration (the size of the read-out at that concentration, not a potency): 69.8%
For compound 3 the middle estimate is 10.2 percentage points above the measured one; low and high end bracket the measured number.
By their numbers in this assay, from the lowest: compounds 3, 2 and 1 (each within the scatter of the next, the first and the last beyond it).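

In this assay this aromatic carbon no longer looks silent: the step of a number 11.7 percentage points lower from compound 1 to compound 3 (beyond the scatter) with methyl in place of hydrogen passes beyond the scatter, if only modestly, whereas the step of a number 1.9 percentage points lower from compound 1 to compound 2 (within the scatter) with chloro in place of hydrogen does not. The direct exchange of chloro for methyl, the step of a number 9.8 percentage points lower from compound 2 to compound 3 (within the scatter) on the same carbon, stays within the scatter, so compound 2 cannot be separated from either of the other two and the two substituents are told apart only in how each compares with hydrogen. No measurement given here bears on why methyl at this carbon gives a step beyond the scatter when chloro does not.

From the compounds shown here alone, it remains open whether an amine, a methoxy group or a carboxylic acid on this aromatic carbon would move the read-out further or leave it within the scatter of compound 1. Going by these compounds, with a single concentration and a single cell line, it also remains open whether the modest step from hydrogen to methyl, a weaker effect at that concentration, would hold at other concentrations or in other cells.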